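The source may hold more compounds than are shown below. What is called first, only, known or untested is meant among the compounds shown, and "the series" means these compounds.

Within the data shown here, in a functional assay on EA.hy 926 cells (Homo sapiens) for cytotoxicity, read by MTT assay, with stated times of 24 h and 12 h, tested at 25 uM (a higher number here means a stronger effect of the compound at the concentration tested, a lower number a weaker effect), compound 1 `CCOC(=O)/C=C/c1ccc(OC)c(OC(=O)c2nc(C)c(C)nc2C)c1` gives 60.1%, the higher of the two numbers known so far. Compound 2 `CCOC(=O)/C=C/c1cc(OC)c(OC(=O)c2nc(C)c(C)nc2C)c(OC)c1` gives 20.9%, a gap beyond the usual scatter. Compound 3 `CCOC(=O)/C=C/c1cccc(OC(=O)c2nc(C)c(C)nc2C)c1` has not yet been tested. It differs from compound 1 in one place: hydrogen in place of methoxy on an aromatic carbon. Among the measured compounds shown here, no step between measured compounds matches this change, so the known data offer no direct guide to its size or direction. Compound 3 is therefore expected to show a step of a number 10.1 percentage points lower from compound 1 to compound 3 (beyond the scatter) that could go either way and need not exceed the scatter. Compound 3 is estimated at 50% in this assay, within a range from 20% to 80%.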

Compound 3, a percentage reported as activity, at one concentration (the size of the read-out at that concentration, not a potency): 34.2%
Compound 3: the middle estimate sits 15.8 percentage points above what was measured; the measured number falls inside the stated range.
By their numbers in this assay, from the lowest: compound 2; then compound 3; then compound 1.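

In this assay, hydrogen in place of methoxy, ortho to a large group and para to a 2-(ethoxycarbonyl)ethenyl group, gives a number 25.9 percentage points lower from compound 1 to compound 3 (beyond the scatter) and is the only single-place step shown. It shows that the read-out responds to this position, with methoxy there giving the larger number. Nothing available explains this step. The compounds shown leave open whether an amine, a fluorine atom or a longer alkoxy chain at this place would match methoxy or hydrogen. They also leave open whether the same change elsewhere on the ring would have a similar effect.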